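Indole and indoline terpenoid esters: growth inhibition notes

This account rests on a few compounds, and the source may have more. Where it says the series, first, only, none or still open, it means among the compounds named here.

Measured compounds:
compound 1 `COC(=O)[C@@]1(C)CCC=C2[C@@H]1CC[C@@H](C)[C@]2(C)Cc1c[nH]c2ccc(C)cc12` — 22000 nM
compound 2 `COC(=O)[C@@]1(C)CCC=C2[C@@H]1CC[C@@H](C)[C@]2(C)Cc1c[nH]c2ccc(C(F)(F)F)cc12` — 18000 nM
compound 3 `COC(=O)[C@@]1(C)CC[C@@H]2C3=C1CC[C@@H](C)[C@]3(C)C[C@@H]1c3ccccc3N[C@H]21` — 50000 nM

In a functional assay on WiDr cells (Homo sapiens) for inhibition, read by sulforhodamine B assay, with a stated time of 48 h (a higher number here means a weaker inhibitor of growth, a lower number a stronger inhibitor of growth), compound 3 stands highest of the three numbers, beyond the scatter from compound 1 and further still from compound 2. Compound 4 `COC(=O)[C@@]1(C)CC[C@@H]2C3=C1CC[C@@H](C)[C@]3(C)C[C@@H]1c3cc(Br)ccc3N[C@H]21` differs from compound 3 by bromo in place of hydrogen on an aromatic carbon. Among the compounds with values here, the only measured step that touches a substituent on the aromatic ring is a 1.2-fold lower number from compound 1 to compound 2 (0.09 log units; within the scatter), an exchange of two groups on the indole core rather than the indoline core of compound 3, and it stayed within the scatter. Within the data shown here, no step on the core of compound 3 has been measured. A small step is therefore expected, a 1.3-fold lower number from compound 3 to compound 4 (0.10 log units; within the scatter), with no change beyond the scatter. Compound 4 is expected to give about 40000 nM, in a range from 15000 nM to 110000 nM.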

Compound 4, concentration for 50% growth inhibition: 55000 nM
Compound 4: middle estimate off by 1.4-fold (0.14 log units), on the low side; low and high end bracket the measured number.
By their numbers in this assay, from the lowest: compounds 2 and 1 (each within the scatter of the next); then compounds 3 and 4 (each within the scatter of the next).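

In this assay, bromo in place of hydrogen on this aromatic carbon gives a 1.1-fold higher number from compound 3 to compound 4 (0.04 log units; within the scatter). Within the data shown here, this is the first measured step on the core of compound 3, and it shows that one bromine at this position leaves the number within the scatter. Nothing measured on this pair offers an explanation for the result.

Still open, going by these compounds, is whether an amine or a carboxylic acid on this aromatic carbon would move the number beyond the scatter. The compounds shown also leave open the effect of replacing the methyl ester, which all four compounds carry, with a carboxylic acid.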